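Turning the amide around on a pyrazole EP1 ligand

The compounds below may be only part of what the source reports. "The series", "measured", "known", "first", "only" and "open" are said of these compounds alone.

Three compounds share one core and differ only in the group on one aromatic carbon. Compound 1 `CNC(=O)c1cc(C)n(Cc2cc(Cl)ccc2OCc2ccccc2)n1` carries a methylcarbamoyl group there; in an assay on CHO-K1 cells for displacement of a labelled ligand from prostaglandin E2 receptor EP1 subtype (Homo sapiens) (on this read-out higher numbers stand for weaker inhibition and lower numbers for stronger inhibition), compound 1 gives 100 nM, the highest number of the three, so it is the weakest binder of the set. Compound 2 `Cc1cc(NC(=O)CC(C)(C)C)nn1Cc1cc(Cl)ccc1OCc1ccccc1` gives 10 nM and compound 3 `Cc1cc(NC(=O)CC2CCCCC2)nn1Cc1cc(Cl)ccc1OCc1ccccc1` gives 6.31 nM. The step of a 10-fold lower number from compound 1 to compound 2 (1.00 log units; beyond the scatter) and the step of a 16-fold lower number from compound 1 to compound 3 (1.20 log units; beyond the scatter) both exchange the methylcarbamoyl group for a nitrogen-linked carbonyl group bearing a larger carbon group, while the step of a 1.6-fold lower number from compound 2 to compound 3 (0.20 log units; within the scatter) shows that the choice between those two carbon groups hardly matters.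

Compound 4 `Cc1cc(NC(=O)OCc2ccccc2)nn1Cc1cc(Cl)ccc1OCc1ccccc1` follows the same pattern: (benzyloxycarbonyl)amino in place of methylcarbamoyl on an aromatic carbon. Here too the ring carbon bears a nitrogen followed by a carbonyl, now with a benzyl group on oxygen. Because a 10-fold lower number from compound 1 to compound 2 (1.00 log units; beyond the scatter) and a 16-fold lower number from compound 1 to compound 3 (1.20 log units; beyond the scatter) were both beyond the scatter, a step of similar size and direction is expected, an 8.3-fold lower number from compound 1 to compound 4 (0.92 log units; beyond the scatter). Compound 4 is therefore estimated at 12 nM, with a range from 3 nM to 50 nM.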

Compound 4, half-maximal inhibitory concentration: 79.4 nM
Estimate against measurement, compound 4: 6.6-fold (0.82 log units) below, and the stated range ends below it.
By their numbers in this assay, from the lowest: compounds 3 and 2 (each within the scatter of the next); then compounds 4 and 1 (each within the scatter of the next).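

In this assay, the exchange of methylcarbamoyl for (benzyloxycarbonyl)amino brings no clear change (a 1.3-fold lower number from compound 1 to compound 4 (0.10 log units; within the scatter)). A nitrogen followed by a carbonyl on this aromatic carbon is therefore not enough on its own to give the stronger binding of compound 2 and compound 3. What stands on the carbonyl carbon also counts, as benzyloxy gives clearly weaker binding than either neopentyl (a 7.9-fold higher number from compound 2 to compound 4 (0.90 log units; beyond the scatter)) or cyclohexylmethyl (a 13-fold higher number from compound 3 to compound 4 (1.10 log units; beyond the scatter)).

The compounds shown leave open whether the oxygen or the benzyl part of benzyloxy goes with this weaker binding; a phenethyl group, with carbon in place of that oxygen, and a tert-butoxy group on the carbonyl carbon would separate the two. Nothing available here explains the difference between benzyloxy and the two carbon groups.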